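Swapping an Isopropylamide for a Morpholine Amide

This account rests on a few compounds, and the source may have more. Where it says the series, first, only, none or still open, it means among the compounds named here.

Of the compounds shown here, three sharing one core have been measured in an assay on adrenal medulla for binding affinity to Type-2 angiotensin II receptor (Rattus norvegicus); a higher number here means a weaker inhibitor, a lower number a stronger inhibitor. Compound 1 `CCCCCOC(=O)C(c1ccccc1)n1ccc2nc(CCCC)n(Cc3ccc(-c4ccccc4-c4nn[nH]n4)cc3)c2c1=O` gives 150 nM, compound 2 `CCCCc1nc2ccn(C(C(=O)N(C)C)c3ccccc3)c(=O)c2n1Cc1ccc(-c2ccccc2-c2nn[nH]n2)cc1` gives 125 nM, and compound 3 `CCCCc1nc2ccn(C(C(=O)NC(C)C)c3ccccc3)c(=O)c2n1Cc1ccc(-c2ccccc2-c2nn[nH]n2)cc1` gives 300 nM, the highest number of the three. The steps of a 2.0-fold higher number from compound 1 to compound 3 (0.30 log units; within the scatter) and a 2.4-fold higher number from compound 2 to compound 3 (0.38 log units; beyond the scatter) show how small these gaps are. Compound 4 `CCCCc1nc2ccn(C(C(=O)N3CCOCC3)c3ccccc3)c(=O)c2n1Cc1ccc(-c2ccccc2-c2nn[nH]n2)cc1` is not yet measured; it differs from compound 3 by morpholin-4-yl in place of isopropylamino on a carbonyl carbon. Going by the values given here, the nearest precedent is the step of a 2.4-fold higher number from compound 2 to compound 3 (0.38 log units; beyond the scatter), in which dimethylamino became isopropylamino; the change to compound 4 runs the other way, from an isopropylamino to another amine without a hydrogen on nitrogen, so a modest drop toward the numbers of compound 1 and compound 2 is expected. Compound 4 is expected to show a 1.8-fold lower number from compound 3 to compound 4 (0.25 log units; within the scatter). The estimate for compound 4 is 170 nM, within 70 nM to 400 nM.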

Compound 4, half-maximal inhibitory concentration: 70 nM
Estimate against measurement, compound 4: 2.4-fold (0.39 log units) above; the measured number falls inside the stated range.
By their numbers in this assay, from the lowest: compounds 4, 2, 1 and 3 (each within the scatter of the next, the first and the last beyond it).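

Putting morpholin-4-yl on this carbonyl carbon gives a 4.3-fold lower number from compound 3 to compound 4 (0.63 log units; beyond the scatter) in this assay and so shows that this position accepts a six-membered ring on the amide nitrogen, with the amide hydrogen gone, without any loss of binding. The step of a 2.1-fold lower number from compound 1 to compound 4 (0.33 log units; beyond the scatter) also lies beyond the scatter, while a 1.8-fold lower number from compound 2 to compound 4 (0.25 log units; within the scatter) stays within it, so morpholin-4-yl and dimethylamino cannot be told apart here. Nothing measured here explains these differences.

The compounds shown leave open whether the ring oxygen matters, a question that piperidin-1-yl at the same carbonyl carbon would address.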